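Adding 4-hydroxybenzyl to the amide nitrogen of compound 3

The source may report more compounds than this note shows. Statements on the series, on what has been measured and on what is new or still open speak of the compounds shown alone.

compound 1 `CC(C)OC(=O)COC(=O)c1ccc([N+](=O)[O-])o1` gives > 100000 nM (a limit)
compound 2 `CC(C)(C)NC(=O)COC(=O)c1ccc([N+](=O)[O-])o1` gives > 100000 nM (a limit)
compound 3 `O=C(COC(=O)c1ccc([N+](=O)[O-])o1)NCC1CCCO1` gives > 100000 nM (a limit)

In an ADME assay on MT4 cells (Homo sapiens) for cytotoxicity, read by MTT assay, with a stated time of 3 days (a higher number here means that more compound is tolerated, a lower number that less compound is tolerated), compound 3 stands at > 100000 nM and this is a limit, not a number. It is not alone there, for the series shows the limit of > 100000 nM in this assay, at which 3 of the 3 values shown sit, and so offers no exact value to start from.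

The next structure is compound 4 `O=C(OCC(=O)N(Cc1ccc(O)cc1)CC1CCCO1)c1ccc([N+](=O)[O-])o1` which keeps the rest of compound 3 and changes one place. The change is 4-hydroxybenzyl in place of hydrogen on an amide-type nitrogen and in words it is 4-hydroxybenzyl in place of hydrogen on an amide-type nitrogen.

The measured steps give no size to carry over. They are a step that the two limits leave unreadable from compound 1 to compound 2 and a step that the two limits leave unreadable from compound 1 to compound 3 and a step that the two limits leave unreadable from compound 2 to compound 3 and none of them replaces the amide hydrogen.

Compound 3 gives > 100000 nM as a limit, so any readable change in this assay is expected to run toward less compound tolerated. The estimated move is an at least 1.6-fold lower number from compound 3 to compound 4 (0.22 log units; that floor lies within the scatter) and its size is only a loose expectation. For compound 4 the estimated value is 60000 nM with an expected range from 15000 nM to 100000 nM. A limit in place of a number would also fit this expectation.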

Compound 4, half-maximal cytotoxic concentration: > 100000 nM
Compound 4: only a limit was reported; the forecaster's own chance of this, stated with the estimate: 50%; middle value at least 1.6-fold (0.22 log units) away from the limit.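

In this assay compound 4 gives > 100000 nM, which is a limit and not a number. Compound 3 is also reported only as a limit, so no step can be read between compound 3 and compound 4. All the compounds shown stand at the same point: the limit of > 100000 nM in this assay, at which 4 of the 4 values shown sit. On these data alone, it remains open at what concentration any of them harms these cells, and whether 4-hydroxybenzyl in place of hydrogen on the amide-type nitrogen changes that concentration.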